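From an Acid Chloride to an Acetoxyamino Amide

A few compounds are considered here, and "the series" means these few. Any claim that something is new, unique, unknown or untested is made for them only; others in the source may bear on it.

Compound 1, `O=C(Cl)/C=C/c1ccccc1OC(=O)c1ccccc1`, carries a chloro on its carbonyl carbon. In a functional assay on A549 cells (Homo sapiens) for inhibition, read by ELISA, with a stated time of 24 h (on this read-out lower numbers stand for stronger inhibition of growth and higher numbers for weaker inhibition of growth), compound 1 gives > 100000 nM, which is a limit of the assay rather than a number. Compound 2, `CO/N=C/C=C/c1ccccc1OC(=O)c1ccccc1`, also gives only a limit in this assay, namely > 100000 nM. Because the limit of > 100000 nM in this assay, at which 2 of the 3 values shown sit, covers both of these values, the step that the two limits leave unreadable from compound 1 to compound 2 cannot be read, and compound 1 therefore stands on a limit alone, with one further value shown that is likewise a limit. For the measured compounds named here, compound 3, `COc1ccccc1/C=C/C(=O)NO`, is the one compound with a number: in this assay compound 3 gives 53500 nM.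

Compound 4 is `CC(=O)ONC(=O)/C=C/c1ccccc1OC(=O)c1ccccc1`. Compared with compound 1 the change is acetoxyamino in place of chloro on a carbonyl carbon. No measured step bears directly on this change, since the only step shown is unreadable. The nearest guide is compound 3, whose value of 53500 nM comes from a chain ending in a hydroxyamino amide, a group that shares its nitrogen-bearing carbonyl with the acetoxyamino of compound 4. Compound 4 is therefore expected to land near that level, at an estimated 50000 nM, within a range from 15000 nM to 200000 nM. From compound 1 this estimate means an expected step of an at least 2.0-fold lower number from compound 1 to compound 4 (0.30 log units; that floor lies within the scatter), though its size cannot be judged against a limit.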

Compound 4, concentration for 50% growth inhibition: 30200 nM
Estimate against measurement, compound 4: 1.7-fold (0.22 log units) above, and the stated range covers the measured number.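

For the compounds shown here, on the carbonyl carbon of the shared core, acetoxyamino in place of chloro gives the first readable change in this assay: an at least 3.3-fold lower number from compound 1 to compound 4 (0.51 log units; beyond the scatter). The other comparison, in which a larger group replaces the one on a double-bonded chain carbon, shows an at least 3.3-fold lower number from compound 2 to compound 4 (0.51 log units; beyond the scatter), so two different starting groups both give way to a measurable number once the acetoxyamino amide is present. Both steps are floors rather than true sizes, because compound 1 and compound 2 rest on the same limit of the assay: the limit of > 100000 nM in this assay, at which 2 of the 4 values shown sit.

The compounds shown leave open whether acetoxyamino itself matters or whether a simpler group on the same carbonyl carbon, such as an amine or a hydroxyl giving the carboxylic acid, would also bring the number down from the limit. Compound 3 differs from compound 4 in more than one place, so its value cannot show what the hydroxyamino group would do on the core of compound 4, and a direct comparison of the two groups on that core remains to be seen.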